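The compounds below may be only part of what the source reports. "The series", "measured", "known", "first", "only" and "open" are said of these compounds alone.

Measured in a functional assay on CNE-2 cells (Homo sapiens) for antiproliferative activity, read by sulforhodamine B assay, with a stated time of 48 h; on this read-out lower numbers stand for stronger inhibition and higher numbers for weaker inhibition:
compound 1 `COc1cc(C=C(C(=O)/C=C/c2cccc(OC)c2OC)C(=O)/C=C/c2cccc(OC)c2OC)ccc1O`, 280 nM
compound 2 `COc1cccc(/C=C/C(=O)C(=Cc2ccc(O)c(F)c2)C(=O)/C=C/c2cccc(OC)c2OC)c1OC`, 260 nM
compound 3 `COc1cc(OC)c(/C=C/C(=O)C(=Cc2ccc(O)c(OC)c2)C(=O)/C=C/c2c(OC)cc(OC)cc2OC)c(OC)c1`, 1350 nM

Compound 1 and compound 2 differ in one place: fluoro in place of methoxy on an aromatic carbon. In this assay that change gave a 1.1-fold lower number from compound 1 to compound 2 (0.03 log units; within the scatter). Compound 3 carries a different core; the difference between the core of compound 1 and the core of compound 3 is not broken down here, and compound 3 stands highest of the three, beyond the scatter from both others.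

Compound 4 `COc1cc(OC)c(/C=C/C(=O)C(=Cc2ccc(O)c(F)c2)C(=O)/C=C/c2c(OC)cc(OC)cc2OC)c(OC)c1` is not yet measured. It differs from compound 3 by fluoro in place of methoxy on an aromatic carbon, the same change, at a place described in the same words, as that from compound 1 to compound 2. Given a 1.1-fold lower number from compound 1 to compound 2 (0.03 log units; within the scatter), a similarly small step is expected, a 1.1-fold lower number from compound 3 to compound 4 (0.05 log units; within the scatter). Compound 4 is estimated at 1200 nM, within 600 nM to 2400 nM.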

Compound 4, half-maximal inhibitory concentration: 1580 nM
For compound 4 the middle estimate is 1.3-fold (0.12 log units) below the measured one; the range from low to high includes it.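

Fluoro in place of methoxy, read as 4-hydroxy-3-methoxyphenyl to 3-fluoro-4-hydroxyphenyl, gives a 1.2-fold higher number from compound 3 to compound 4 (0.07 log units; within the scatter) in this assay, and this step agrees with the earlier one: the same change on two cores in this assay, a 1.1-fold lower number (0.03 log units; within the scatter) from compound 1 to compound 2 and a 1.2-fold higher number (0.07 log units; within the scatter) from compound 3 to compound 4, 1.3-fold (0.10 log units) apart, within the scatter of two such steps.
On these two cores, then, the swap carries over as a step within the scatter, whichever core holds it. This rests on two cores and one assay, so it says nothing about a third core, and nothing about what separates the core of compound 1 from the core of compound 3.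

Still open, as far as these compounds go, is whether chloro, a nitrile or an amine at this place would give a step beyond the scatter. Also open, from the compounds shown here alone, is what an amine or a carboxylic acid would do in place of the hydroxy group, which all four compounds carry.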